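Swapping fluoro for trifluoromethyl at the assay limit

The compounds below may be only part of what the source reports. "The series", "measured", "known", "first", "only" and "open" are said of these compounds alone.

In a functional assay on KYSE-410 cells (Homo sapiens) for antiproliferative activity, read by MTT assay, with a stated time of 72 h (on this read-out higher numbers stand for weaker inhibition and lower numbers for stronger inhibition), compound 1 (`O=C(Nc1ccc(C(F)(F)F)cc1)c1cc(=O)[nH]c2cc(Br)ccc12`) gives > 20000 nM as a limit and not a number. Compound 2 (`O=C(Nc1cccc(F)c1)c1cc(=O)[nH]c2cc(F)ccc12`) gives > 20000 nM as a limit too. Compound 3 (`O=C(Nc1cc(F)cc(F)c1)c1cc(=O)[nH]c2cc(F)ccc12`) stands at > 20000 nM as a limit as well.

Compound 4 (`O=C(Nc1cc(F)cc(F)c1)c1cc(=O)[nH]c2cc(C(F)(F)F)ccc12`) has trifluoromethyl in place of fluoro on an aromatic carbon of compound 3, with trifluoromethyl in place of fluoro on an aromatic carbon as the counted change. The nearest measured step is a step that the two limits leave unreadable from compound 2 to compound 3 and it exchanges a different pair, fluoro in place of hydrogen, so it offers no size to carry over. The record so far is the limit of > 20000 nM in this assay, at which 3 of the 3 values shown sit, and it holds no number to build on. No step beyond the scatter is therefore expected in this assay in either direction, although a small move toward stronger inhibition remains possible. The expected change is a number no higher from compound 3 to compound 4 (the limit leaves the size open) as an estimate only. For compound 4 the estimated value is 20000 nM with an expected range from 8000 nM to 40000 nM around that estimate.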

Compound 4, half-maximal inhibitory concentration: 17900 nM
Compound 4: middle estimate off by 1.1-fold (0.05 log units), on the high side, and the stated range covers the measured number.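

In this assay compound 4 gives 17900 nM as a true number and not a limit, the first such reading among the compounds shown, so a core carrying trifluoromethyl at this aromatic carbon comes into the measurable range. The change is read as an at least 1.1-fold lower number from compound 3 to compound 4 (0.04 log units; that floor lies within the scatter) and only that floor is known, so the data show neither a real gain in strength nor how large the true step is. Most of the record still gives no number to compare with: the limit of > 20000 nM in this assay, at which 3 of the 4 values shown sit.

As far as these compounds go, whether an amine, a methoxy group or a carboxylic acid on this same aromatic carbon would give a clearly lower number stays open. Also open, from the compounds shown here alone, is whether trifluoromethyl here would give a number with a different set of groups on the amide's aromatic ring.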